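Swapping the Aniline Ring Substituents on a Shared Core

The compounds below may be only part of what the source reports. "The series", "measured", "known", "first", "only" and "open" are said of these compounds alone.

Of the compounds shown here, three built on a shared core have been measured in a functional assay on NCI-H1975 cells (Homo sapiens) for inhibition, read by MTT assay, with a stated time of 72 h; a higher number here means a weaker inhibitor, a lower number a stronger inhibitor. Compound 1 `O=C(CSc1nc(Nc2ccccc2)c2ccccc2n1)Nc1cccc(Br)c1` gives 10100 nM, and compound 2 `CCc1cccc(NC(=O)CSc2nc(Nc3ccccc3)c3ccccc3n2)c1` gives 12000 nM. Among the measured compounds shown here, the only single-point step among them, a 1.2-fold higher number from compound 1 to compound 2 (0.07 log units; within the scatter), shows that exchanging the group on the amide-bearing ring made no difference beyond the scatter. Compound 3 `C=CC(=O)Nc1cccc(NC(=O)CSc2nc(Nc3cccc(F)c3)c3ccccc3n2)c1` gives 2030 nM, the lowest of the three numbers; it differs from compound 1 and compound 2 in two places at once, so its advantage cannot be tied to one change.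

Compound 4 `C=CC(=O)Nc1cccc(NC(=O)CSc2nc(Nc3ccc(F)c(Cl)c3)c3ccccc3n2)c1` is not yet measured. The change from compound 3 is 3-chloro-4-fluorophenyl in place of 3-fluorophenyl on a nitrogen on an aromatic ring. For the measured compounds named here, no measured step touches this ring, and the one step that exists, on a different ring, stayed within the scatter. A modest movement, if any, is therefore expected: the estimated step of a 1.4-fold lower number from compound 3 to compound 4 (0.13 log units; within the scatter) is small. Compound 4 is expected to give about 1500 nM, within a range from 500 nM to 5000 nM.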

Compound 4, half-maximal inhibitory concentration: > 50000 nM
Compound 4 gave a limit, no number; the forecaster's own chance of this, stated with the estimate: 5%; middle value at least 33-fold (1.52 log units) from the limit.
By their numbers in this assay, from the lowest: compound 3; then compounds 1 and 2 (each within the scatter of the next). At a limit, above all of these: compound 4.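

Compound 4 shows that the group on a nitrogen on an aromatic ring can matter a great deal: 3-chloro-4-fluorophenyl in place of 3-fluorophenyl gives an at least 24-fold higher number from compound 3 to compound 4 (1.39 log units; beyond the scatter), whereas the earlier step on the other ring, a 1.2-fold higher number from compound 1 to compound 2 (0.07 log units; within the scatter), gave no sign of such sensitivity. The two groups are close in size, with 8 heavy atoms against 7 and the same six-membered aromatic ring of carbon only, so a small structural change here can produce a large step. For compound 4, the reading in this assay is a limit and not a number: the limit of > 50000 nM in this assay, at which 1 of the 4 values shown sits.

The compounds shown do not separate the added chlorine from the changed fluorine pattern, since both differences arrive together. As far as these compounds go, how a ring carrying chlorine alone, fluorine alone, a methoxy group or an amine would behave at this position remains open.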